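The source may hold more compounds than are shown below. What is called first, only, known or untested is meant among the compounds shown, and "the series" means these compounds.

Of the compounds shown here, three built on a shared core have been tested in a functional assay on MCF7 cells (Homo sapiens) for antiproliferative activity, read by MTT assay, with a stated time of 72 h; a lower number here means a stronger inhibitor of growth, a higher number a weaker inhibitor of growth. Compound 1 `Cn1nc(-c2ccnc(Nc3ccc(O)cc3)n2)c2ccccc21` gives 8910 nM. Compound 2 `Cc1ccc(Nc2nccc(-c3nn(C)c4ccccc34)n2)cc1` gives 6100 nM. Compound 3 `Cc1cccc(Nc2nccc(-c3nn(C)c4ccccc34)n2)c1` gives 9150 nM. On these numbers compound 3 has the highest value of the three, but the gaps are small: a 1.0-fold higher number from compound 1 to compound 3 (0.01 log units; within the scatter) and a 1.5-fold higher number from compound 2 to compound 3 (0.18 log units; within the scatter), and likewise a 1.5-fold lower number from compound 1 to compound 2 (0.16 log units; within the scatter). All three sit together within the usual scatter, so none of them can be called a stronger or weaker inhibitor of growth than the others.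

Compound 4 `Cn1nc(-c2ccnc(Nc3cccc([N+](=O)[O-])c3)n2)c2ccccc21` has not yet been measured. It differs from compound 3 in one place: nitro in place of methyl on an aromatic carbon. The measured steps that bear on this change are those that alter the group on the same phenyl ring, whether a methyl replaced a hydroxy or a 3-methylphenyl replaced a 4-methylphenyl. Each of those steps stayed within the scatter. Nothing in these data shows a group on this ring moving the number beyond the scatter, so the expectation is a step in this assay of no more than the scatter, in no clear direction: a 1.1-fold lower number from compound 3 to compound 4 (0.03 log units; within the scatter). Compound 4 is therefore estimated at 8500 nM, with a range from 3500 nM to 20000 nM.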

Compound 4, concentration for 50% growth inhibition: 580 nM
Beside the measured number, compound 4's estimate is 15-fold (1.17 log units) above it, and the stated range ends above it.
By their numbers in this assay, from the lowest: compound 4; then compounds 2, 1 and 3 (each within the scatter of the next).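

In this assay, putting nitro in place of methyl on the aromatic carbon meta to a large group gives a 16-fold lower number from compound 3 to compound 4 (1.20 log units; beyond the scatter), the only step among these compounds that lies beyond the scatter. The earlier changes on this phenyl ring, such as methyl in place of hydroxy or a 3-methylphenyl in place of a 4-methylphenyl, left the number within the scatter, so they gave no sign that the ring could matter; this step shows that the group at this position can change growth inhibition by a large margin. The entering nitro brings more heavy atoms and two hydrogen-bond acceptors where methyl has none, but no measurement here connects the stronger inhibition with these counts or with any other feature of the group, and so the data offer no explanation for the step.

On these data alone, it remains open whether the low number is particular to nitro or would also appear with a nitrile, an amine or a carboxylic acid at the same carbon. The compounds shown also leave open whether nitro would have a similar effect at another carbon of this ring.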